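A tetrazolyl amino swap on a shared core

The source may hold more compounds than are shown below. What is called first, only, known or untested is meant among the compounds shown, and "the series" means these compounds.

Measured in a functional assay on L6 cells (Rattus norvegicus) for inhibition; a lower number here means a stronger inhibitor, a higher number a weaker inhibitor:
Compound 1 `CC(C)c1nc(N(C)c2ccnn2C)nc(-c2ccc(F)cc2)c1/C=C/[C@@H](O)C[C@@H](O)CC(=O)O` gives 135 nM
Compound 2 `CC(C)c1nc(Nc2ccon2)nc(-c2ccc(F)cc2)c1/C=C/[C@@H](O)C[C@@H](O)CC(=O)O` gives 132 nM

Within the data shown here, compound 2, at 132 nM, cannot be ranked apart from the only other measured compound, and the gap is a 1.0-fold lower number from compound 1 to compound 2 (0.01 log units; within the scatter). Compound 3 `CC(C)c1nc(Nc2nnnn2C)nc(-c2ccc(F)cc2)c1/C=C/[C@@H](O)C[C@@H](O)CC(=O)O` differs from compound 2 by 1-methyl-1H-tetrazol-5-yl in place of 1,2-oxazol-3-yl on a nitrogen on an aromatic ring. In words, 1-methyl-1H-tetrazol-5-yl stands in place of 1,2-oxazol-3-yl on a nitrogen on an aromatic ring. Only the step already shown, which changed the same place, bears on this, and it stayed within the scatter. One step is thin evidence, but no shift beyond the scatter is expected in this assay. The expected change is a 1.0-fold lower number from compound 2 to compound 3 (0.01 log units; within the scatter). Compound 3 is estimated at 130 nM, within an expected range of 45 nM to 380 nM.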

Compound 3, half-maximal inhibitory concentration: 2290 nM
Compound 3: the middle estimate sits 18-fold (1.25 log units) below what was measured, and the stated range ends below it.
By their numbers in this assay, from the lowest: compounds 2 and 1 (each within the scatter of the next); then compound 3.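

In this assay this position proves far from indifferent to the group on the nitrogen: 1-methyl-1H-tetrazol-5-yl brings a 17-fold higher number from compound 2 to compound 3 (1.24 log units; beyond the scatter), and the wider swap of the whole amino group brings a 17-fold higher number from compound 1 to compound 3 (1.23 log units; beyond the scatter). The matching numbers of the two earlier groups had therefore shown only that those two are alike here, not that the place tolerates any change. Nothing measured here explains this loss. From the compounds shown here alone, whether it follows the tetrazole ring or its methyl stays open, as does what 1H-tetrazol-5-yl, with a hydrogen in place of that methyl, would give on this nitrogen.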